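Chain Lengthening of an Azide Tail on Two Related Cores

The compounds below may be only part of what the source reports. "The series", "measured", "known", "first", "only" and "open" are said of these compounds alone.

Four compounds built on closely related cores are compared in a functional assay on aorta (Rattus norvegicus, strain Wistar) for inhibition; a higher number here means that more compound is needed for the effect, a lower number that less compound is needed. Compound 1 `Cn1c(=O)c2c(Cl)cccc2c(=O)n1CCN=[N+]=[N-]` gives 4120 nM in this assay. Compound 2 `Cn1c(=O)c2c(Cl)cccc2c(=O)n1CCCN=[N+]=[N-]` carries a longer tail; the difference is azidomethyl in place of azido on a saturated chain carbon, two bonds along the chain from an aromatic nitrogen. In this assay compound 2 gives 2330 nM, so the step of a 1.8-fold lower number from compound 1 to compound 2 (0.25 log units; within the scatter) is a small one.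

Compound 3 `Cn1c(=O)c2cccc(Cl)c2c(=O)n1CCN=[N+]=[N-]` shares its atoms with compound 1 but has them joined differently; the difference between the two cores is not broken down here. In this assay compound 3 gives 6350 nM, a value that sits close to that of compound 1 and is clearly higher than that of compound 2.

Compound 4 `Cn1c(=O)c2cccc(Cl)c2c(=O)n1CCCN=[N+]=[N-]` has not yet been measured. It stands to compound 3 as compound 2 stands to compound 1: the difference is azidomethyl in place of azido on a saturated chain carbon, two bonds along the chain from an aromatic nitrogen, the same change at the same place. Because the earlier step of a 1.8-fold lower number from compound 1 to compound 2 (0.25 log units; within the scatter) stayed small, the step from compound 3 to compound 4 is expected to be of about the same size, a 1.8-fold lower number from compound 3 to compound 4 (0.26 log units; within the scatter), which rests on that single prior example. On that basis compound 4 is estimated to give 3500 nM in this assay. The estimate for compound 4 is expected to fall between 1500 nM and 8000 nM.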

Compound 4, half-maximal effective concentration: 4310 nM
Compound 4: middle estimate off by 1.2-fold (0.09 log units), on the low side; low and high end bracket the measured number.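

In this assay the new measurement gives a 1.5-fold lower number from compound 3 to compound 4 (0.17 log units; within the scatter), so putting azidomethyl in place of azido on a saturated chain carbon, two bonds along the chain from an aromatic nitrogen, is again a small step, this time on the second core. Set side by side, the two steps agree: the same change on two cores in this assay, a 1.8-fold lower number (0.25 log units; within the scatter) from compound 1 to compound 2 and a 1.5-fold lower number (0.17 log units; within the scatter) from compound 3 to compound 4, 1.2-fold (0.08 log units) apart, within the scatter of two such steps. For this one change, the step carried over from the core of compound 1 to the core of compound 3 with no difference that can be told apart, but both steps lie within the scatter, so this does not show that the longer tail really shifts the number at all, and two cores cannot promise the same result on a third.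

All four compounds shown end in an azide, which leaves open how a longer chain, or an amine or a carboxylic acid at the end of the tail, would behave in this assay. Also open, going by these compounds, is whether the step would stay this small with a bromine or a methyl group in place of the chlorine on the core.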